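This account rests on a few compounds, and the source may have more. Where it says the series, first, only, none or still open, it means among the compounds named here.

Compound 1, `Cc1ccc(Nc2nc3ncccc3n2Cc2ccccc2)cc1[N+](=O)[O-]`, gives 40400 nM in a functional assay on HCT-116 cells (Homo sapiens) for antiproliferative activity, read by MTT assay, with a stated time of 72 h; on this read-out higher numbers stand for weaker inhibition of growth and lower numbers for stronger inhibition of growth.
Compound 2, `c1ccc(Cn2c(Nc3ccccc3)nc3cccnc32)cc1`, gives 60200 nM in this assay.
Compound 3, `Cn1nc(-c2ccnc(Nc3ccc(O)cc3)n2)c2ccccc21`, gives 8430 nM in this assay.

Compound 3 has the lowest number of the three, and its gap to compound 1 and to compound 2 is in each case beyond the scatter, so it is the strongest of the measured set. Compound 4, `Cn1nc(-c2ccnc(Nc3cccc(Cl)c3)n2)c2ccccc21`, differs from compound 3 in one place: 3-chlorophenyl in place of 4-hydroxyphenyl on a nitrogen on an aromatic ring. Within the data shown here, no measured pair shows what this exchange does, so the expectation rests on compound 3 alone and is uncertain in both size and direction. A modest weakening from compound 3 to compound 4 is expected, a 1.5-fold higher number from compound 3 to compound 4 (0.19 log units; within the scatter), with a range wide enough to include no change. Compound 4 is estimated at 13000 nM, between 3000 nM and 50000 nM.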

Compound 4, concentration for 50% growth inhibition: 6400 nM
Compound 4: middle estimate off by 2.0-fold (0.31 log units), on the high side; the range from low to high includes it.
By their numbers in this assay, from the lowest: compounds 4 and 3 (each within the scatter of the next); then compounds 1 and 2 (each within the scatter of the next).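

On a nitrogen on an aromatic ring, the exchange of 4-hydroxyphenyl for 3-chlorophenyl gives a 1.3-fold lower number from compound 3 to compound 4 (0.12 log units; within the scatter) in this assay. The hydrogen-bond donor and acceptor of 4-hydroxyphenyl are therefore not needed at this position to keep this level of growth inhibition in these two compounds. No measurement at hand explains the result. On these data alone, the exchange alters both the group on the phenyl ring and its place, so the share of each stays open. An amine or a carboxylic acid on that ring is also an open case.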